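Urea Chain Swap: Aryl to Cyclohexyl on Compound 1

The source may report more compounds than this note shows. Statements on the series, on what has been measured and on what is new or still open speak of the compounds shown alone.

Measured compounds:
Compound 1 `O=C(Nc1cccc(Cl)c1)Nc1cccc(CNc2nccnc2Cl)c1` gives 6810 nM.
Compound 2 `CC(C)(C)c1ccc(NC(=O)Nc2cccc(CNc3nccnc3Cl)c2)cc1` gives 6010 nM.
Compound 3 `CS(=O)(=O)c1ccc(NC(=O)Nc2cccc(CNc3nccnc3Cl)c2)cc1` gives 29300 nM.

In a functional assay on T-24 cells (Homo sapiens) for antiproliferative activity, read by MTT assay, with a stated time of 48 h (a lower number here means a stronger inhibitor, a higher number a weaker inhibitor), compound 1 stands second highest of the three, close to compound 2 and well apart from compound 3. The unmeasured compound 4 `O=C(Nc1cccc(CNc2nccnc2Cl)c1)NC1CCCCC1` differs from compound 1 by cyclohexyl in place of 3-chlorophenyl on an amide-type nitrogen. Going by the values given here, the only measured step, a 4.9-fold higher number from compound 2 to compound 3 (0.69 log units; beyond the scatter), concerns a substituent on the distal aryl ring rather than the ring itself, so it bears only loosely on this change. Among the compounds with values here, with no step of the same kind available, the expectation rests on compound 1 alone, and a shift within or just beyond the scatter is expected, most likely toward a higher number. Compound 4 is therefore estimated at 9500 nM, a step of a 1.4-fold higher number from compound 1 to compound 4 (0.14 log units; within the scatter), with a range of 3000 nM to 30000 nM.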

Compound 4, half-maximal inhibitory concentration: > 40000 nM
Compound 4: only a limit was reported; the forecaster's own chance of this, stated with the estimate: 10%; middle value at least 4.2-fold (0.62 log units) away from the limit.
By their numbers in this assay, from the lowest: compounds 2 and 1 (each within the scatter of the next); then compound 3. At a limit, above all of these: compound 4.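

The earlier compounds shown here varied only substituents on the aromatic ring, whereas this change replaces the ring itself. In this assay, compound 4 is reported only as a limit: the limit of > 40000 nM in this assay, at which 1 of the 4 values shown sits. Cyclohexyl in place of 3-chlorophenyl on this amide-type nitrogen gives an at least 5.8-fold higher number from compound 1 to compound 4 (0.76 log units; beyond the scatter), so a non-aromatic ring of carbon only does not retain the activity of compound 1 at this position.

Going by these compounds, how far the true value of compound 4 lies past its limit remains open. On these data alone, whether a benzyl group or a longer alkyl chain on this nitrogen would restore activity also remains open.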